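The compounds below may be only part of what the source reports. "The series", "measured", "known", "first", "only" and "open" are said of these compounds alone.

Working notes on the series. Compound 1 `COc1cc(Br)cc(/C=C/C(=O)c2ccccc2)c1O` and compound 2 `COc1cc(Br)cc(/C=C/C(=O)c2ccc(Cl)cc2)c1O` share one core; compound 3 `COc1cc(Br)cc2c1OC(N)=C(C#N)C2CC(=O)c1ccccc1` and the as yet unmeasured compound 4 `COc1cc(Br)cc2c1OC(N)=C(C#N)C2CC(=O)c1ccc(Cl)cc1` share another, and the difference between the two cores is not broken down here. In an ADME assay on MCF-10A cells (Homo sapiens) for cytotoxicity, read by sulforhodamine B assay, with a stated time of 72 h, tested at 30 uM (a lower number here means a weaker effect, a higher number a stronger effect of the compound at the concentration tested), compound 1 gives 40.7% and compound 2 gives 47.8%, a step of a number 7.1 percentage points higher from compound 1 to compound 2 (within the scatter) brought about by chloro in place of hydrogen on an aromatic carbon. In this assay compound 3 gives 45.9%. The change from compound 3 to compound 4 is chloro in place of hydrogen on an aromatic carbon, the same change as before, the place being described in the same words. The step is expected to be a number 5.1 percentage points higher from compound 3 to compound 4 (within the scatter), resting on the step of a number 7.1 percentage points higher from compound 1 to compound 2 (within the scatter) seen on the other core. Compound 4 is therefore estimated at 51%, with a range from 38% to 63%.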

Compound 4, a percentage reported as activity, at one concentration (the size of the read-out at that concentration, not a potency): 41.6%
Beside the measured number, compound 4's estimate is 9.4 percentage points above it, within the range that was stated.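

In this assay, chloro in place of hydrogen on an aromatic carbon gives a number 4.3 percentage points lower from compound 3 to compound 4 (within the scatter). Set beside the same change on the core of compound 1, the two steps do not differ: the same change on two cores in this assay, a number 7.1 percentage points higher (within the scatter) from compound 1 to compound 2 and a number 4.3 percentage points lower (within the scatter) from compound 3 to compound 4, 11.4 percentage points apart, within the scatter of two such steps. Since each step lies within the scatter, this shows no measurable effect of the change on either core and no difference between the cores, but it does not show that the change has no effect or that the two cores respond identically.

The compounds shown carry only hydrogen or chloro at this place. As far as these compounds go, whether an amine or a carboxylic acid in place of the chloro would give a step beyond the scatter on either core remains open.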